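Methoxy for Pyridinylsulfanyl: Expecting a Return to Lower Numbers

The source may report more compounds than this note shows. Statements on the series, on what has been measured and on what is new or still open speak of the compounds shown alone.

Of the compounds shown here, two have so far been measured in a functional assay for inhibition of sodium/hydrogen exchanger (Oryctolagus cuniculus); a higher number here means a weaker inhibitor, a lower number a stronger inhibitor. Compound 1 `CCc1cc(C)c(C(=O)N=C(N)N)cc1S(C)(=O)=O`, which carries an ethyl group, gives 4.8 nM. Compound 2 `Cc1cc(Sc2ccncc2)c(S(C)(=O)=O)cc1C(=O)N=C(N)N` gives 13 nM, the higher of the two numbers. For the measured compounds named here, its only measured neighbour is compound 1, and the single step in the set runs a 2.7-fold higher number from compound 1 to compound 2 (0.43 log units; beyond the scatter). Compound 3 `COc1cc(C)c(C(=O)N=C(N)N)cc1S(C)(=O)=O` has not yet been measured. It differs from compound 2 in one place: methoxy in place of (pyridin-4-yl)sulfanyl on an aromatic carbon. Going by the values given here, no measured pair sets methoxy against ethyl on the shared core, so the only evidence that bears on this change is the step of a 2.7-fold higher number from compound 1 to compound 2 (0.43 log units; beyond the scatter), in which the pyridin-4-ylsulfanyl group replaced ethyl and the number rose modestly. Taking that group away again in favour of methoxy is therefore expected to undo much of that step, and the estimated change is a modest move to a lower number, a 2.2-fold lower number from compound 2 to compound 3 (0.34 log units; beyond the scatter). Compound 3 is accordingly expected to give about 6 nM in this assay, with a likely range from 2.5 nM to 15 nM.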

Compound 3, half-maximal inhibitory concentration: 16 nM
Compound 3: middle estimate off by 2.7-fold (0.43 log units), on the low side; the whole stated range lies below it.
By their numbers in this assay, from the lowest: compound 1; then compounds 2 and 3 (each within the scatter of the next).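

In this assay, methoxy in place of (pyridin-4-yl)sulfanyl gives a 1.2-fold higher number from compound 2 to compound 3 (0.09 log units; within the scatter), so on this aromatic carbon, ortho to a methylsulfonyl group, the read-out does not separate a group of 7 heavy atoms carrying a six-membered aromatic ring from a group of 2 heavy atoms with no ring. The direct comparison of methoxy with ethyl on the shared core gives a 3.3-fold higher number from compound 1 to compound 3 (0.52 log units; beyond the scatter), which shows that the rise seen on leaving ethyl does not need the pyridine ring: methoxy, with no ring at all, shows it too, and among these three groups only ethyl stands at the lower number. Nothing measured here accounts for why ethyl stands apart from the other two groups.

The compounds shown do not tell whether the lower number belongs to ethyl alone or extends to a propyl chain or an isopropyl group on this carbon. They also leave open whether an amine or a phenylsulfanyl group here would stand with ethyl or with methoxy and (pyridin-4-yl)sulfanyl.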